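A few compounds are considered here, and "the series" means these few. Any claim that something is new, unique, unknown or untested is made for them only; others in the source may bear on it.

Measured compounds in an in vitro ADME assay on microsomes from liver (Rattus norvegicus) for metabolic stability, with a stated time of 30 min; a higher number here means faster removal of the compound, a lower number slower removal:

compound 1 `COc1ccccc1C(=O)NC(=O)Nc1ccc(-c2ccccc2)c(C(C)C)c1`, a limit of the assay: < 14 mL.min-1.g-1
compound 2 `COc1ccncc1C(=O)NC(=O)Nc1ccc(-c2ccccc2)c(C(F)(F)F)c1`, a limit of the assay: < 14 mL.min-1.g-1
compound 3 `COc1ccccc1C(=O)NC(=O)Nc1ccc(N2CCCCC2)c(C(F)(F)F)c1`, intrinsic clearance in microsomes: 26 mL.min-1.g-1

Compound 3 is the only one of the three that gives a number; the other two sit at the limit (the limit of < 14 mL.min-1.g-1 in this assay, at which 2 of the 3 values shown sit). Among the measured compounds shown here, no step between measured compounds differs in one place, so nothing is known directly about the size of any single change.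

Compound 4 `COc1ccccc1C(=O)NC(=O)Nc1ccc(-c2ccccc2)c(C(F)(F)F)c1` is not yet measured. It differs from compound 3 by phenyl in place of piperidin-1-yl on an aromatic carbon.

Compound 4 shares the aryl substitution of compound 1 and compound 2, which both sit at the limit (the limit of < 14 mL.min-1.g-1 in this assay, at which 2 of the 3 values shown sit), so a small step downward is expected from compound 3, a 2.2-fold lower number from compound 3 to compound 4 (0.34 log units; beyond the scatter), with a fair chance that only a limit is reported. The estimate for compound 4 is 12 mL.min-1.g-1, expected between 5 mL.min-1.g-1 and 28 mL.min-1.g-1.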

Compound 4, intrinsic clearance in microsomes in the Rattus norvegicus assay: 15 mL.min-1.g-1
Compound 4: middle estimate off by 1.3-fold (0.10 log units), on the low side, and the stated range covers the measured number.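

In the Rattus norvegicus assay, phenyl in place of piperidin-1-yl gives a 1.7-fold lower number from compound 3 to compound 4 (0.24 log units; within the scatter), so this change shows no clear effect on clearance. In the Rattus norvegicus assay, 2-methoxyphenyl in place of 4-methoxypyridin-3-yl gives an at least 1.0-fold higher number from compound 2 to compound 4 (0.02 log units; that floor lies within the scatter), which is only a floor. In the Rattus norvegicus assay, trifluoromethyl in place of isopropyl gives an at least 1.0-fold higher number from compound 1 to compound 4 (0.02 log units; that floor lies within the scatter), which is also only a floor. In a physicochemical assay for solubility (on this read-out higher numbers stand for higher solubility and lower numbers for lower solubility), compound 3 gives 3 ug/mL. In the physicochemical assay compound 4 gives < 1 ug/mL, which is a limit of the assay.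

As far as these compounds go, with that limit, an at least 3.0-fold lower number from compound 3 to compound 4 (0.47 log units; beyond the scatter) is only a floor, and the full size of the drop stays open. Also open, from the compounds shown here alone, is whether a morpholine on this aromatic carbon would restore solubility while keeping clearance unchanged.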